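Swapping a Phenyl for a Tert-Butoxy Group

The compounds below may be only part of what the source reports. "The series", "measured", "known", "first", "only" and "open" are said of these compounds alone.

This series builds on a shared core seen in compound 1 `CS(=O)(=O)c1cc(C(=O)N=C(N)N)c(F)cc1F`, which carries no group at the position of interest. In a functional assay for inhibition of sodium/hydrogen exchanger (Oryctolagus cuniculus) (a higher number here means a weaker inhibitor, a lower number a stronger inhibitor), compound 1 gives 630 nM. Compound 2 `Cc1cc(-c2cc(C(F)(F)F)cc(C(F)(F)F)c2)c(S(C)(=O)=O)cc1C(=O)N=C(N)N` places a phenyl bearing two trifluoromethyl groups at that position; in this assay compound 2 gives 2800 nM. Compound 3 `Cc1cc(-c2ccccc2)c(S(C)(=O)=O)cc1C(=O)N=C(N)N` carries a plain phenyl there, and in this assay compound 3 gives 19 nM, the lowest of the three numbers: compound 1 sits at a higher number beyond the scatter, and compound 2 sits further still, also beyond the scatter.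

Compound 4 `Cc1cc(OC(C)(C)C)c(S(C)(=O)=O)cc1C(=O)N=C(N)N` is not yet measured. It differs from compound 3 in one place: tert-butoxy in place of phenyl on an aromatic carbon.

Among the compounds with values here, no pair among the measured compounds differs in just one place, so no single step is known. Still, a move away from the plain phenyl of compound 3 toward a group with fewer heavy atoms and no ring is expected to push the number upward, though far less than the drop to no group at all, since compound 1 gives 630 nM. The expected step of a 3.2-fold higher number from compound 3 to compound 4 (0.50 log units; beyond the scatter) is modest, toward a weaker inhibitor. In this assay compound 4 is estimated at 60 nM, with a likely range from 15 nM to 250 nM.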

Compound 4, half-maximal inhibitory concentration: 9.4 nM
Estimate against measurement, compound 4: 6.4-fold (0.81 log units) above, outside the stated range (below it).
By their numbers in this assay, from the lowest: compound 4; then compound 3; then compound 1; then compound 2.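

In this assay, putting tert-butoxy in place of phenyl on this aromatic carbon gives a 2.0-fold lower number from compound 3 to compound 4 (0.31 log units; beyond the scatter). The step shows that a six-membered aromatic ring is not required here for a low number: a group with no ring, and with one hydrogen-bond acceptor where phenyl has none, gives a number lower than the one for the plain phenyl, by a modest margin that still lies beyond the usual scatter. No measurement at hand bears on the reason for this step, so it stands as an observation without an explanation.

The compounds shown cannot say which part of tert-butoxy matters, the oxygen that links it to the ring or the branched carbon group on that oxygen; methoxy, isopropoxy and a tert-butyl group joined directly to the ring would begin to separate these two parts. Also open, from the compounds shown here alone, is how very different groups at this position would compare with tert-butoxy and phenyl, such as an amine like piperidine or a carboxylic acid.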